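The source may report more compounds than this note shows. Statements on the series, on what has been measured and on what is new or still open speak of the compounds shown alone.

Of the compounds shown here, three sharing one core have been measured in a functional assay on HepG2 cells (Homo sapiens) for antiproliferative activity, read by MTT assay, with a stated time of 72 h (on this read-out higher numbers stand for weaker inhibition and lower numbers for stronger inhibition), and they differ in the group on an amide-type nitrogen in a ring. Compound 1 `COc1ncc(-c2ccc3c(c2)N(c2ccc(F)cc2)C(=O)CO3)cc1NS(=O)(=O)c1ccc(F)cc1` carries 4-fluorophenyl there and gives 36400 nM in this assay. Compound 2 `COc1ncc(-c2ccc3c(c2)N(C2CCCCC2)C(=O)CO3)cc1NS(=O)(=O)c1ccc(F)cc1` carries cyclohexyl, and its reading of > 40000 nM is a limit of the assay, not a number. Compound 3 `COc1ncc(-c2ccc3c(c2)N(c2ccccc2)C(=O)CO3)cc1NS(=O)(=O)c1ccc(F)cc1` carries phenyl and gives 14000 nM, the lowest number of the set. Its lead is modest but beyond the scatter: a 2.6-fold lower number from compound 1 to compound 3 (0.41 log units; beyond the scatter) and an at least 2.8-fold lower number from compound 2 to compound 3 (0.45 log units; beyond the scatter). The remaining comparison, an at least 1.0-fold higher number from compound 1 to compound 2 (0.04 log units; that floor lies within the scatter), rests on a limit and shows no clear separation.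

Among the measured compounds shown here, compound 4 `COc1ncc(-c2ccc3c(c2)N(C2CC2)C(=O)CO3)cc1NS(=O)(=O)c1ccc(F)cc1` keeps the core and changes only this group: cyclopropyl in place of phenyl on an amide-type nitrogen in a ring. In words, it has cyclopropyl in place of phenyl on an amide-type nitrogen in a ring. The closest guide is the measured step of an at least 2.8-fold lower number from compound 2 to compound 3 (0.45 log units; beyond the scatter), which, read in reverse, suggests that losing phenyl for a non-aromatic ring raises the number. That guide is a single pair, and it rests on a limit, so only a modest rise is expected. The expected change is a 2.1-fold higher number from compound 3 to compound 4 (0.33 log units; beyond the scatter). For compound 4 the estimated value is 30000 nM, within an expected range of 12000 nM to 70000 nM.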

Compound 4, half-maximal inhibitory concentration: 14400 nM
The estimate for compound 4 lay 2.1-fold (0.32 log units) above the measured number; measured number inside the range.
By their numbers in this assay, from the lowest: compounds 3 and 4 (each within the scatter of the next); then compound 1. At a limit, above all of these: compound 2.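

In this assay, cyclopropyl in place of phenyl on the amide-type nitrogen in a ring gives a 1.0-fold higher number from compound 3 to compound 4 (0.01 log units; within the scatter), so the two groups cannot be told apart here, although the entering ring is non-aromatic and has 3 heavy atoms against 6. A non-aromatic ring at this position is therefore not tied to a higher number, as the earlier comparison of cyclohexyl with phenyl alone might have suggested: cyclopropyl also gives a 2.5-fold lower number from compound 1 to compound 4 (0.40 log units; beyond the scatter) and an at least 2.7-fold lower number from compound 2 to compound 4 (0.44 log units; beyond the scatter), which sets it apart from both 4-fluorophenyl and cyclohexyl. Compound 2 reads > 40000 nM, which is a limit of the assay and not a number, so the second of those steps gives only a floor: the limit of > 40000 nM in this assay, at which 1 of the 4 values shown sits.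

Every group shown at this position is a carbon ring, apart from the fluoro of compound 1, so how a cyclopentyl ring, an open ethyl chain or an amine-bearing chain would read on this nitrogen remains open. Since only this one position varies, the compounds also leave open whether any group here could bring the number far below those seen so far.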